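A few compounds are considered here, and "the series" means these few. Any claim that something is new, unique, unknown or untested is made for them only; others in the source may bear on it.

Among the compounds with values here, compound 1 `C=CC[C@H]1C[C@]2([C@@H](C)Cc3ccc(OC)cc3)OCOC2=CC1=O` is the only compound of this set with a number in a functional assay on M14 cells (Homo sapiens) for antiproliferative activity, with a stated time of 72 h; a higher number here means a weaker inhibitor, a lower number a stronger inhibitor; in this assay compound 1 gives 20 nM. Compound 2 `C=CC[C@H]1C[C@]2([C@@H](C)Cc3ccc(OC(F)(F)F)cc3)OCOC2=CC1=O` carries a trifluoromethyl in place of methyl on the oxygen on the aromatic ring, and in this assay compound 2 reaches only a limit, > 20000 nM, not a number. The step of an at least 1000-fold higher number from compound 1 to compound 2 (3.00 log units; beyond the scatter) is thus known only as a floor, its size set by the limit of > 20000 nM in this assay, at which 1 of the 2 values shown sits.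

Compound 3 `C=CC[C@H]1C[C@]2([C@@H](C)Cc3ccc(OC)c(C(=O)NC)c3)OCOC2=CC1=O` has not yet been measured in this assay. It differs from compound 1 by methylcarbamoyl in place of hydrogen on an aromatic carbon. Within the data shown here, the methoxy group, the site of the one measured step, is kept, and no measured step adds a group on a ring carbon, so the recorded step bears on this change only by showing that a change of the substitution on this aromatic ring can drive the value to the limit. He expects a moderate weakening for compound 3 in this assay, a 10-fold higher number from compound 1 to compound 3 (1.00 log units; beyond the scatter). His estimate for compound 3 in this assay is 200 nM, within a range from 20 nM to 5000 nM.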

Compound 3, half-maximal inhibitory concentration: 1400 nM
For compound 3 the middle estimate is 7.0-fold (0.85 log units) below the measured one, within the range that was stated.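

Within the data shown here, the ring carbon that carries the new group had not been touched by the earlier compounds, whose one step changed only the group on the oxygen. Here the methoxy group stays in place and methylcarbamoyl enters ortho to it, and in this assay this single addition gives a 70-fold higher number from compound 1 to compound 3 (1.85 log units; beyond the scatter), so the aromatic ring responds strongly to a change on a ring carbon as well as on the oxygen. Compound 3 still keeps a measured value in the micromolar-free sense of a real number rather than a limit, which makes this the first change on the ring whose full size can be read, whereas the step to compound 2 ends at a limit: the limit of > 20000 nM in this assay, at which 1 of the 3 values shown sits.

The compounds shown leave open whether the loss follows the whole methylcarbamoyl group or only a part of it, which a plain carboxamide, a dimethylcarbamoyl group or a methyl ester at the same place could separate. They also leave open whether a small group on this carbon, such as fluorine or methyl, would be tolerated in this assay.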